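From 3-methylphenyl to naphthalen-2-yl on the shared core

A few compounds are considered here, and "the series" means these few. Any claim that something is new, unique, unknown or untested is made for them only; others in the source may bear on it.

Compound 1 (`COC(=O)c1c(C)cc(OC(=O)c2c(C)cc(O)c(/C=N/NC(=O)COc3ccccc3C)c2O)c(C)c1O`) and compound 2 (`COC(=O)c1c(C)cc(OC(=O)c2c(C)cc(O)c(/C=N/NC(=O)COc3cccc(C)c3)c2O)c(C)c1O`) differ only in the methylphenyl group on the oxygen. In an ADME assay on HEK293 cells (Homo sapiens) for cytotoxicity (a lower number here means a stronger inhibitor, a higher number a weaker inhibitor), compound 1 gives > 100000 nM, which is a limit of the assay and not a number. In this assay compound 2 gives > 100000 nM, likewise a limit and not a number. Compound 2 therefore has no readable value, and the whole picture so far is the limit of > 100000 nM in this assay, at which 2 of the 2 values shown sit. Among the compounds with values here, the only measured step is a step that the two limits leave unreadable from compound 1 to compound 2, so it offers no size to carry forward.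

Compound 3 (`COC(=O)c1c(C)cc(OC(=O)c2c(C)cc(O)c(/C=N/NC(=O)COc3ccc4ccccc4c3)c2O)c(C)c1O`) carries naphthalen-2-yl in place of 3-methylphenyl on an oxygen on a saturated carbon. Within the data shown here, no measured step shows how far a change at this place can move this assay. The most likely outcome is therefore another reading at the limit, and a measurable number would be expected to fall on the stronger side of it. The expected step is an at least 1.1-fold lower number from compound 2 to compound 3 (0.04 log units; that floor lies within the scatter), an estimate of modest size. For compound 3 the estimate is 90000 nM, with an expected range of 30000 nM to 200000 nM.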

Compound 3, half-maximal inhibitory concentration: 52700 nM
For compound 3 the middle estimate is 1.7-fold (0.23 log units) above the measured one; measured number inside the range.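

In this assay, within the data shown here, this place, on an oxygen on a saturated carbon, now gives a readable number for the first time: with naphthalen-2-yl and its 2 six-membered aromatic rings in place of 3-methylphenyl, the result is an at least 1.8-fold lower number from compound 2 to compound 3 (0.27 log units; that floor lies within the scatter), and in place of 2-methylphenyl it is an at least 1.8-fold lower number from compound 1 to compound 3 (0.27 log units; that floor lies within the scatter). Going by these compounds, both steps start from a limit, so each is only a floor whose true size stays unknown, and as printed neither floor clears the scatter, while the step between the two methylphenyl compounds cannot be read at all. The change therefore gives the series one number to work from, and the rest of the picture is unchanged: the limit of > 100000 nM in this assay, at which 2 of the 3 values shown sit.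

With one readable compound, no trend at this place can be drawn from the carbon count or ring count of the group. Still open, on these data alone, is whether a different kind of group on this oxygen, such as a phenyl ring carrying a carboxylic acid or an aminoethyl chain, would stay at the limit or give a number on either side of compound 3.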